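Methyl to hydroxy in a series with little spread

A few compounds are considered here, and "the series" means these few. Any claim that something is new, unique, unknown or untested is made for them only; others in the source may bear on it.

In a functional assay, read by Griess assay, with a stated time of 2.5 h (a lower number here means a stronger inhibitor, a higher number a weaker inhibitor), compound 1 (`COc1cc(OC)c(OC)cc1/C=C/C(=O)c1ccc(Cl)cc1`) reads 2.01 ug/mL and compound 2 (`COc1ccc(C(=O)/C=C/c2cc(OC)c(OC)cc2OC)cc1`) reads 2.07 ug/mL while compound 3 (`COc1cc(OC)c(OC)cc1/C=C/C(=O)c1ccc(C)cc1`) reads 2.18 ug/mL and so stands level with both, inside the scatter. Compound 4 (`COc1cc(OC)c(OC)cc1/C=C/C(=O)c1ccc(O)cc1`) alters one group of compound 3 (hydroxy in place of methyl on an aromatic carbon), with hydroxy in place of methyl on an aromatic carbon, para to a large group. The measured swaps on that carbon were all small: a 1.1-fold higher number from compound 1 to compound 3 (0.04 log units; within the scatter) and a 1.1-fold higher number from compound 2 to compound 3 (0.02 log units; within the scatter) and also a 1.0-fold higher number from compound 1 to compound 2 (0.01 log units; within the scatter) and each lies within the scatter. None of them brings in a hydroxy, so the forecast stays loose. No step beyond the scatter is expected (a 1.0-fold lower number from compound 3 to compound 4 (0.02 log units; within the scatter)). The estimated value for compound 4 is 2.1 ug/mL (expected range 1 ug/mL to 4.5 ug/mL).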

Compound 4, half-maximal inhibitory concentration: 2.5 ug/mL
Compound 4: middle estimate off by 1.2-fold (0.08 log units), on the low side; low and high end bracket the measured number.
By their numbers in this assay, from the lowest: compounds 1, 2, 3 and 4 (each within the scatter of the next).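

In this assay a hydroxy on this aromatic carbon, para to a large group, brings in a hydrogen-bond donor, yet the reading stays level with the methyl (a 1.1-fold higher number from compound 3 to compound 4 (0.06 log units; within the scatter)) and with the chloro (a 1.2-fold higher number from compound 1 to compound 4 (0.09 log units; within the scatter)). Taking the methyl off the methoxy oxygen gives the same picture (a 1.2-fold higher number from compound 2 to compound 4 (0.08 log units; within the scatter)), so chloro, methoxy, methyl and hydroxy all sit here without a step beyond the scatter. No evidence is available to explain this flatness. Going by these compounds, whether an amine, a carboxylic acid or a longer chain on this carbon would also read level remains open.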